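Thiosemicarbazones: aryl swap on the thioamide nitrogen

A few compounds are considered here, and "the series" means these few. Any claim that something is new, unique, unknown or untested is made for them only; others in the source may bear on it.

Measured compounds:
compound 1, `S=C(N/N=C/c1ccc2ccccc2n1)Nc1ccc(Br)cc1`, 56800 nM
compound 2, `NC(=S)N/N=C/c1cc2ccccc2s1`, 6770 nM

In a functional assay on HeLa cells (Homo sapiens) for antiproliferative activity, read by sulforhodamine B assay, with a stated time of 72 h (a higher number here means a weaker inhibitor, a lower number a stronger inhibitor), compound 1 gives 56800 nM, the highest of the two numbers in hand. Among the measured compounds shown here, compound 2 does not share the core of compound 1 and carries no aryl group on its thioamide nitrogen; in this assay compound 2 gives 6770 nM; the gap between the two values lies beyond the scatter, but no single-site step connects them, so the two numbers say only that compound 1 is the weaker of the pair.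

Compound 3, `Fc1ccccc1NC(=S)N/N=C/c1ccc2ccccc2n1`, keeps the core of compound 1 and differs from it in one place: 2-fluorophenyl in place of 4-bromophenyl on an amide-type nitrogen. For the measured compounds named here, no measured step of this kind exists, so nothing in hand shows how such a swap moves this assay. The expected step from compound 1 to compound 3 in this assay is therefore small, a 1.3-fold lower number from compound 1 to compound 3 (0.10 log units; within the scatter), with no firm direction beyond the scatter.

Compound 3 is estimated at 45000 nM, within 15000 nM to 130000 nM.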

Compound 3, half-maximal inhibitory concentration: > 100000 nM
Compound 3 was reported as a limit; the forecaster's own chance of this, stated with the estimate: 20%; middle value at least 2.2-fold (0.34 log units) from the limit.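

In this assay compound 3 gives > 100000 nM, which is a limit of the assay and not a number. Placing 2-fluorophenyl in place of 4-bromophenyl on the amide-type nitrogen gives the first measured step at this position, an at least 1.7-fold higher number from compound 1 to compound 3 (0.24 log units; that floor lies within the scatter), so the series now has a direct reading for an aryl swap on the thioamide nitrogen of the shared core, though only as a floor. The size of the step stays unfixed and that floor cannot be called beyond the scatter, so the comparison gives a bound and not a measured difference: the limit of > 100000 nM in this assay, at which 1 of the 3 values shown sits.

This single step changes both the halogen and its place on the phenyl ring, so 4-bromophenyl and 2-fluorophenyl alone cannot separate the two changes, and 4-fluorophenyl or 2-bromophenyl on the same nitrogen would be needed for that. Also open, as far as these compounds go, is how this assay responds on the core of compound 1 to a non-aryl group at this nitrogen, such as a morpholine ring or a short aminoalkyl chain, or to a plain phenyl ring with no halogen.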